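Swapping the styryl-thiazole for a chlorophenyl in a cinnamate series

The source may report more compounds than this note shows. Statements on the series, on what has been measured and on what is new or still open speak of the compounds shown alone.

Compound 1 `COC(=O)/C=C/c1cccc(N(Cc2ccc(/C=C/c3cccc(F)c3)cc2)C(=O)C(C)C)c1`: 71 nM
Compound 2 `COC(=O)/C=C/c1cccc(N(Cc2ccc(/C=C/c3scnc3C)cc2)C(=O)C2CCCCC2)c1`: 227 nM
Compound 3 `COC(=O)/C=C/c1cccc(N(Cc2ccc(/C=C/c3scnc3C)cc2)C(=O)C(C)C)c1`: 228 nM

In an assay on isolated protein with Bile acid receptor (Homo sapiens) as the target (a higher number here means that more compound is needed for the effect, a lower number that less compound is needed), compound 2 gives 227 nM, the second highest of the three numbers; its step to compound 3 lies within the scatter, while compound 1 sits a clear step lower. Compound 4 `COC(=O)/C=C/c1cccc(N(Cc2ccc(-c3cccc(Cl)c3)cc2)C(=O)C2CCCCC2)c1` differs from compound 2 by 3-chlorophenyl in place of 2-(4-methyl-1,3-thiazol-5-yl)ethenyl on an aromatic carbon. Among the compounds with values here, one measured step bears on this: a 3.2-fold higher number from compound 1 to compound 3 (0.51 log units; beyond the scatter), showing that a halophenyl group is favoured over the thiazole. Within the data shown here, no measured pair speaks to the loss of the ethenyl link, so that part is uncertain. For compound 4 a modest lowering is therefore expected, a 1.9-fold lower number from compound 2 to compound 4 (0.28 log units; within the scatter), giving an estimate of 120 nM with a range from 40 nM to 400 nM.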

Compound 4, half-maximal effective concentration: 94 nM
For compound 4 the middle estimate is 1.3-fold (0.11 log units) above the measured one; the measured number falls inside the stated range.
By their numbers in this assay, from the lowest: compounds 1 and 4 (each within the scatter of the next); then compounds 2 and 3 (each within the scatter of the next).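

In this assay, setting 3-chlorophenyl directly on the aromatic carbon, para to a large group, gives a 2.4-fold lower number from compound 2 to compound 4 (0.38 log units; beyond the scatter), so this position does not need the ethenyl link for a lower number. The ring and the link change together in this step, so it cannot be divided between them. No measurement on hand explains the step. Going by these compounds, it remains open how 3-chlorophenyl would read when joined through an ethenyl link, and how a carboxylic acid in place of the methyl ester would read in this assay.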